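Cytotoxicity notes on a quinolinone benzylamine series

The compounds below may be only part of what the source reports. "The series", "measured", "known", "first", "only" and "open" are said of these compounds alone.

Measured so far:
compound 1 `CCOc1ccc(CN(Cc2ccc(C(C)(C)C)cc2)Cc2cc3cc(C)ccc3[nH]c2=O)cc1`: > 10000 nM
compound 2 `Cc1ccc2[nH]c(=O)c(CN(Cc3ccc(OC(C)C)cc3)Cc3ccc(C(C)(C)C)cc3)cc2c1`: > 5000 nM
compound 3 `Cc1ccc2[nH]c(=O)c(CN(Cc3ccc(C(C)(C)C)cc3)C(C)c3ccc(F)cc3)cc2c1`: > 33000 nM

In a toxicity assay on MDCK cells (Canis lupus familiaris) for cytotoxicity, read by crystal violet staining, with a stated time of 48 h (on this read-out higher numbers stand for lower toxicity in this test and lower numbers for higher toxicity in this test), compound 1 gives only a limit, (the limit of > 10000 nM in this assay, at which 1 of the 3 values shown sits). Compound 2 likewise gives only a limit, (the limit of > 5000 nM in this assay, at which 1 of the 3 values shown sits). Compound 3 also gives only a limit, (the limit of > 33000 nM in this assay, at which 1 of the 3 values shown sits).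

The change from compound 1 to compound 2 is methyl in place of hydrogen on a saturated chain carbon bound to an oxygen on an aromatic ring and a saturated chain carbon, and its step is a step that the two limits leave unreadable from compound 1 to compound 2 because both ends are limits (the limit of > 10000 nM in this assay, at which 1 of the 3 values shown sits, (the limit of > 5000 nM in this assay, at which 1 of the 3 values shown sits)). The cores of compound 1 and compound 3 differ by 1-(4-fluorophenyl)ethyl in place of 4-ethoxybenzyl on an amine nitrogen, a step read as a step that the two limits leave unreadable from compound 1 to compound 3.

Compound 4 `CCc1ccc2[nH]c(=O)c(CN(Cc3ccc(C(C)(C)C)cc3)C(C)c3ccc(F)cc3)cc2c1` is not yet measured. It differs from compound 3 by methyl in place of hydrogen on a saturated chain carbon bound to an aromatic carbon. This is the same kind of change as that from compound 1 to compound 2, not the same one: there the place was on a saturated chain carbon bound to an oxygen on an aromatic ring and a saturated chain carbon, here it is on a saturated chain carbon bound to an aromatic carbon.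

In this assay compound 4 is expected to move by a step that the limit leaves unreadable from compound 3 to compound 4, resting on compound 3 giving only a limit, > 33000 nM. Compound 4 is estimated at 40000 nM.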

Compound 4, half-maximal cytotoxic concentration: 2800 nM
Compound 4: the middle estimate sits 14-fold (1.15 log units) above what was measured, and the stated range ends above it.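

In this assay, methyl in place of hydrogen on a saturated chain carbon bound to an aromatic carbon, read as methyl to ethyl, gives an at least 11-fold lower number from compound 3 to compound 4 (1.07 log units; beyond the scatter), so the number moves towards higher toxicity in this test on this one core. As far as these compounds go, compound 3 gives only a limit, so the full size of the step stays unknown: the limit of > 33000 nM in this assay, at which 1 of the 4 values shown sits. The same kind of change on a saturated chain carbon bound to an oxygen on an aromatic ring and a saturated chain carbon links compound 1 and compound 2, but that step and all others ending in two limits cannot be read, so nothing here shows whether the shift carries over to another core or another place.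

From the compounds shown here alone, it remains open whether methyl to ethyl gives a step of similar size with 4-ethoxybenzyl or 4-isopropoxybenzyl on the amine nitrogen in place of 1-(4-fluorophenyl)ethyl. Also open, going by these compounds, is how a longer chain such as propyl, or an amine or a carboxylic acid, would read in that place.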